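This account rests on a few compounds, and the source may have more. Where it says the series, first, only, none or still open, it means among the compounds named here.

Three compounds have been measured in an assay on isolated protein for binding affinity to somatostatin receptor type 4 (Homo sapiens), read by radioligand binding; on this read-out higher numbers stand for weaker inhibition and lower numbers for stronger inhibition:

Compound 1 `NCCCCCOC[C@H]1O[C@@H](OCCc2c[nH]c3ccccc23)[C@H](OCc2ccccc2)[C@@H](OCc2ccccc2)[C@@H]1OCc1ccccn1` gives 890 nM
Compound 2 `NCCCCCOC[C@H]1O[C@@H](OCCc2c[nH]c3ccccc23)[C@H](OCc2ccccc2)[C@@H](OCc2ccccc2)[C@@H]1OCc1ccncc1` gives 570 nM
Compound 3 `NCCCCCOC[C@H]1O[C@@H](OCCc2c[nH]c3ccccc23)[C@H](OCc2ccccc2)[C@@H](OCc2ccccc2)[C@@H]1OCc1ccc(Cl)nc1` gives 1200 nM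

Compound 3 shows the highest of the three numbers. Its distance to compound 1 is within the scatter (a 1.3-fold higher number from compound 1 to compound 3 (0.13 log units; within the scatter)), whereas a 2.1-fold higher number from compound 2 to compound 3 (0.32 log units; beyond the scatter) lies beyond it, if only modestly. Compound 4 `Cc1ccc(CO[C@H]2[C@H](OCc3ccccc3)[C@@H](OCc3ccccc3)[C@H](OCCc3c[nH]c4ccccc34)O[C@@H]2COCCCCCN)cn1` differs from compound 3 by methyl in place of chloro on an aromatic carbon. Among the measured compounds shown here, no measured step bears directly on this change: each of the three steps swaps the whole ring for another, and none of them exceeds a modest size. A methyl entering where chloro leaves, with nothing else altered, is therefore expected to move the number by no more than the scatter, a 1.1-fold lower number from compound 3 to compound 4 (0.04 log units; within the scatter). Compound 4 is estimated at 1100 nM, with a range from 500 nM to 2500 nM.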

Compound 4, inhibition constant in the somatostatin receptor type 4 assay: 1260 nM
For compound 4 the middle estimate is 1.1-fold (0.06 log units) below the measured one; the measured number falls inside the stated range.
By their numbers in the somatostatin receptor type 4 assay, from the lowest: compounds 2, 1, 3 and 4 (each within the scatter of the next, the first and the last beyond it).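

Among the compounds shown here, at the carbon next to the ring nitrogen, methyl and chloro cannot be told apart in the somatostatin receptor type 4 assay (a 1.1-fold higher number from compound 3 to compound 4 (0.02 log units; within the scatter)), which no earlier step, each swapping the whole ring, could show. Against the other rings, compound 4 sits as compound 3 does, with a 1.4-fold higher number from compound 1 to compound 4 (0.15 log units; within the scatter) and a 2.2-fold higher number from compound 2 to compound 4 (0.34 log units; beyond the scatter) matching the steps from compound 3 in what lies within and beyond the scatter. In a physicochemical assay for acid dissociation, compound 3 gives 0.5 and compound 4 gives 6.1. In the physicochemical assay the same change is large, yet it comes with no step beyond the scatter in binding: the measured acid dissociation constant of compound 3, 0.5, and of compound 4, 6.1, a number 5.60 log units higher (beyond the scatter).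

The compounds shown leave open whether a methoxy group or an amine at this carbon would also stay within the scatter of chloro and methyl.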